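A Methyl Group Added to Compound 3

This account rests on a few compounds, and the source may have more. Where it says the series, first, only, none or still open, it means among the compounds named here.

In a functional assay on A2780 cells (Homo sapiens) for antiproliferative activity, read by MTT assay, with a stated time of 72 h (a higher number here means a weaker inhibitor, a lower number a stronger inhibitor), compound 1 `O=C(CCCCCONC(=O)Nc1ccc2ncccc2c1)NO` gives 27300 nM and compound 2 `O=C(CCCCCONC(=O)Nc1cccc2cccnc12)NO` gives 3000 nM while compound 3 `COc1cc(NC(=O)NOCCCCCC(=O)NO)c2ncccc2c1` gives 1200 nM as the lowest number of the three. Compound 4 `COc1cc(NC(=O)NOCCCCCC(=O)NO)c2nccc(C)c2c1` differs from compound 3 by one change (methyl in place of hydrogen on an aromatic carbon), methyl in place of hydrogen on an aromatic carbon, opposite the ring nitrogen. Among the compounds with values here, the one measured step of a similar kind is a 2.5-fold lower number from compound 2 to compound 3 (0.40 log units; beyond the scatter) for methoxy in place of hydrogen on an aromatic carbon, and it is modest. That step involves a different group, so it is only a weak guide. In this assay the estimated step is a 1.3-fold lower number from compound 3 to compound 4 (0.12 log units; within the scatter) and so an expected change no larger than the scatter. For compound 4 the expected value is 900 nM with an estimated range from 350 nM to 2500 nM in this measurement.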

Compound 4, half-maximal inhibitory concentration: 1100 nM
Beside the measured number, compound 4's estimate is 1.2-fold (0.09 log units) below it, and the stated range covers the measured number.
By their numbers in this assay, from the lowest: compounds 4 and 3 (each within the scatter of the next); then compound 2; then compound 1.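

In this assay methyl opposite the ring nitrogen gives a 1.1-fold lower number from compound 3 to compound 4 (0.04 log units; within the scatter) and so adds a carbon at this position with no change beyond the scatter. Compound 2 and compound 3 both carry hydrogen here, so they could not show this. Nothing measured here offers an explanation for the result. From the compounds shown here alone, whether the position accepts something other than methyl, such as an amine, a carboxylic acid or a longer chain, remains open. So does whether methyl would behave the same way on the core of compound 2 without the methoxy group.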